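Replacing a Hydroxypiperidine with a Pyrrolidine on the Side Chain

This account rests on a few compounds, and the source may have more. Where it says the series, first, only, none or still open, it means among the compounds named here.

Compound 1 `Cn1ncc(Cl)c1-c1cc(C(=O)N[C@@H]2CN[C@H](CCN3CCC(O)CC3)C[C@H]2c2ccc(Cl)c(Cl)c2)oc1Cl`: 13700 nM
Compound 2 `CCC[C@@H]1C[C@@H](c2ccc(Cl)c(Cl)c2)[C@H](NC(=O)c2cc(-c3c(Cl)cnn3C)c(Cl)o2)CN1`: 1020 nM
Compound 3 `CC(=O)OCC[C@@H]1C[C@@H](c2ccc(F)c(F)c2)[C@H](NC(=O)c2cc(-c3c(Cl)cnn3C)c(Cl)o2)CN1`: 690 nM

These three compounds were measured in a functional assay on HCT-116 cells (Homo sapiens) for antiproliferative activity, read by sulforhodamine B assay, with a stated time of 72 h; a lower number here means a stronger inhibitor, a higher number a weaker inhibitor. Among them compound 1 has the highest number, that is, it is the weakest inhibitor of the three. The nearest of the others is reached by a 13-fold lower number from compound 1 to compound 2 (1.13 log units; beyond the scatter), a change beyond the scatter. Compound 3 lies further away still, but it differs from compound 1 in more than one place, so only its value can be compared.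

The unmeasured compound 4 `Cn1ncc(Cl)c1-c1cc(C(=O)N[C@@H]2CN[C@H](CCN3CCCC3)C[C@H]2c2ccc(Cl)c(Cl)c2)oc1Cl` differs from compound 1 in one place: pyrrolidin-1-yl in place of 4-hydroxypiperidin-1-yl on a saturated chain carbon, two bonds along the chain from a saturated ring carbon. Among the measured compounds shown here, the one measured step that bears on this is a 13-fold lower number from compound 1 to compound 2 (1.13 log units; beyond the scatter), in which the same 4-hydroxypiperidin-1-yl group left and a methyl entered, giving a large downward step. In compound 4 a pyrrolidin-1-yl enters instead, so a ring amine remains at that position. For the measured compounds named here, a downward step is therefore expected, though probably smaller than the one seen when the group was removed altogether. Compound 4 is estimated at 5000 nM, within a range of 1500 nM to 15000 nM, which would mean an expected step of a 2.7-fold lower number from compound 1 to compound 4 (0.44 log units; beyond the scatter).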

Compound 4, half-maximal inhibitory concentration: 1940 nM
The estimate for compound 4 lay 2.6-fold (0.41 log units) above the measured number, within the range that was stated.
By their numbers in this assay, from the lowest: compounds 3, 2 and 4 (each within the scatter of the next, the first and the last beyond it); then compound 1.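

In this assay, putting pyrrolidin-1-yl in place of 4-hydroxypiperidin-1-yl gives a 7.1-fold lower number from compound 1 to compound 4 (0.85 log units; beyond the scatter) and so shows that the number can fall while a ring amine stays on the chain, whereas the earlier step showed only what happened when that amine was replaced by a methyl. Setting pyrrolidin-1-yl in place of methyl gives a 1.9-fold higher number from compound 2 to compound 4 (0.28 log units; within the scatter) and leaves compound 2 and compound 4 indistinguishable in this assay, so the high number of compound 1 does not go with every ring amine at this place. No measurement shown gives a reason for either step.

The change from 4-hydroxypiperidin-1-yl to pyrrolidin-1-yl alters the ring size and removes the hydroxyl group in one move, so these compounds cannot say which of the two differences matters. A plain piperidin-1-yl group would separate them, while a morpholine ring or an open-chain dimethylamino group would show how far this position tolerates other amines.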